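The source may hold more compounds than are shown below. What is called first, only, known or untested is meant among the compounds shown, and "the series" means these compounds.

In a functional assay on SK-BR-3 cells (Homo sapiens) for antiproliferative activity, read by MTT assay, with a stated time of 72 h (a higher number here means a weaker inhibitor, a lower number a stronger inhibitor), compound 1 `C/C=C1/[C@H](O[C@@H]2O[C@H](COC(C)=O)[C@@H](OC(C)=O)[C@H](OC(C)=O)[C@H]2OC(C)=O)OC=C(C(=O)OC)[C@H]1CC(=O)OCCCCCCCCCCCCCCC` gives 3810 nM. For compound 2 `C#CCOC(=O)C[C@@H]1C(C(=O)OC)=CO[C@@H](O[C@@H]2O[C@H](CO)[C@@H](O)[C@H](O)[C@H]2O)/C1=C/C` this assay returns only a limit, > 15000 nM, so its standing is known as a limit and not as a number; the limit of > 15000 nM in this assay, at which 1 of the 2 values shown sits, shows where that limit sits. Compound 3 `C/C=C1/[C@H](O[C@@H]2O[C@H](CO)[C@@H](O)[C@H](O)[C@H]2O)OC=C(C(=O)OC)[C@H]1CC(=O)OCCCC` is reached by propyl in place of ethynyl on a saturated chain carbon bound to an oxygen next to a carbonyl group. Going by the values given here, no measured step matches this change, and propyl in place of ethynyl offers no footing for a shift beyond the scatter. The step from compound 2 to compound 3 is expected at an at least 1.2-fold lower number from compound 2 to compound 3 (0.09 log units; that floor lies within the scatter). Compound 3 is therefore estimated at 12000 nM, within a range from 4000 nM to 40000 nM, with a limit rather than a number remaining likely.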

Compound 3, half-maximal inhibitory concentration: > 15000 nM
Compound 3 gave a limit, no number; the forecaster's own chance of this, stated with the estimate: 60%; at least 1.2-fold (0.09 log units) between middle value and limit.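

Compound 2 and compound 3 both give only limits in this assay, so no step between them can be read: the limit of > 15000 nM in this assay, at which 2 of the 3 values shown sit.

On these data alone, whether propyl in place of ethynyl changes the antiproliferative read-out at all remains open.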